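Cytotoxicity notes: from compound 2 to compound 3

The source may hold more compounds than are shown below. What is called first, only, known or untested is meant among the compounds shown, and "the series" means these compounds.

compound 1 `O=C(Nc1ncc(C(Oc2ccc3cc(Br)ccc3c2)c2ccc(Cl)cc2)s1)C1CCOCC1`: "not toxic" (no number reported)
compound 2 `O=C(Nc1ncc(C(Oc2ccc3cc(Br)ccc3c2)c2ccc(Cl)cc2)s1)c1ccc(F)cc1Br`: > 50000 nM

In an ADME assay on HepG2 2.2.15 cells (Homo sapiens) for cytotoxicity (on this read-out lower numbers stand for higher toxicity in this test and higher numbers for lower toxicity in this test), compound 1 gives "not toxic" (no number reported). Compound 2 reaches only the limit of the test, > 50000 nM, so no number stands for it; this is the limit of > 50000 nM in this assay, at which 1 of the 2 values shown sits. Among the compounds with values here, both measured compounds thus sit at the non-toxic end, and no step between measured compounds is available. Compound 3 `O=S(=O)(Nc1ncc(C(Oc2ccc3cc(Br)ccc3c2)c2ccc(Cl)cc2)s1)c1ccc2c(c1)CCO2` differs from compound 2 by a group of 12 heavy atoms (8 carbon, 3 oxygen, 1 sulfur; one five-membered non-aromatic ring with 1 hetero atom, one six-membered aromatic ring of carbon only) in place of a group of 10 heavy atoms (7 carbon, 1 oxygen, 1 fluorine, 1 bromine; one six-membered aromatic ring of carbon only), on a nitrogen on an aromatic ring. Within the data shown here, with no measured step to go on, the expected step in this assay is none beyond the scatter, a step that the limit leaves unreadable from compound 2 to compound 3. Compound 3 is estimated at 60000 nM, between 20000 nM and 200000 nM, most likely again reported only as a limit.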

Compound 3, half-maximal cytotoxic concentration: > 50000 nM
Compound 3 ended at the assay's limit; the forecaster's own chance of this, stated with the estimate: 70%; the middle value does not contradict the limit.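

In this assay compound 2 and compound 3 both sit at the limit of the test, and the step between them cannot be read. The compounds shown leave open at what concentration, if any, cytotoxicity would appear for either compound.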